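The compounds below may be only part of what the source reports. "The series", "measured", "known", "first", "only" and "open" are said of these compounds alone.

For the measured compounds named here, compound 2 `Cc1cc(-c2ccccc2C(F)(F)F)cc(C)c1Nc1ccnc(Nc2ccc(C#N)cc2)n1` is one of two compounds so far tested in an ADME assay on MT4 cells (Homo sapiens) for cytotoxicity, read by MTT assay, with a stated time of 4 days; on this read-out lower numbers stand for higher toxicity in this test and higher numbers for lower toxicity in this test. In this assay compound 2 gives 4210 nM, the higher of the two numbers; the other compound, compound 1 `Cc1cc(-c2cccc(C#N)c2)cc(C)c1Nc1ccnc(Nc2ccc(C#N)cc2)n1`, gives 920 nM in this assay. Going by the values given here, the single step measured between them, a 4.6-fold higher number from compound 1 to compound 2 (0.66 log units; beyond the scatter), swapped the entire group sitting on an aromatic carbon of the shared core for a different one. Compound 3 `Cc1cc(-c2ccc(C(F)(F)F)cc2)cc(C)c1Nc1ccnc(Nc2ccc(C#N)cc2)n1` has not yet been measured. It contains the same atoms as compound 2, joined differently: 4-(trifluoromethyl)phenyl in place of 2-(trifluoromethyl)phenyl on an aromatic carbon. Among the compounds with values here, no measured step shifts a trifluoromethyl from one place on that group to another, so the only guide is that the one measured step, a wholesale exchange of the group at the same place, produced only a modest shift. A rearrangement within the same group is expected to change little, and the step of a 1.2-fold lower number from compound 2 to compound 3 (0.08 log units; within the scatter) is expected to fall within the scatter. Compound 3 is therefore estimated at 3500 nM in this assay, within a range from 1200 nM to 10000 nM.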

Compound 3, half-maximal cytotoxic concentration: 4160 nM
For compound 3 the middle estimate is 1.2-fold (0.08 log units) below the measured one, within the range that was stated.
By their numbers in this assay, from the lowest: compound 1; then compounds 3 and 2 (each within the scatter of the next).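

In this assay, 4-(trifluoromethyl)phenyl in place of 2-(trifluoromethyl)phenyl gives a 1.0-fold lower number from compound 2 to compound 3 (0.01 log units; within the scatter), so this test does not separate these two attachment patterns of the trifluoromethyl group on the ring. For the compounds shown here, the earlier compounds could not show this, since their only step exchanged one whole group for another. The second exchange of this kind, 4-(trifluoromethyl)phenyl in place of 3-cyanophenyl, gives a 4.5-fold higher number from compound 1 to compound 3 (0.66 log units; beyond the scatter), so both trifluoromethyl compounds now stand apart from compound 1 in the same direction, towards lower toxicity in this test, and no information is available on what lies behind either step.

Compound 1 differs from the other two both in its group and in where that group sits on the ring, so the compounds shown leave open whether the nitrile itself or its placement accounts for the gap. They also say nothing about how a phenyl ring carrying an amine or a carboxylic acid would behave at this position, or whether a simple alkyl chain in place of the ring would behave differently.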